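This account rests on a few compounds, and the source may have more. Where it says the series, first, only, none or still open, it means among the compounds named here.

Working notes on the series. In a functional assay on UACC-257 cells (Homo sapiens) for inhibition, read by sulforhodamine B assay, with a stated time of 48 h, tested at 10 uM (on this read-out higher numbers stand for more inhibition of growth at the one concentration tested and lower numbers for less inhibition of growth), compound 1 (`CC(=O)c1ccc(NC(=O)Cn2nc(-c3ccc(Cl)cc3)nc2N)cc1`) gives 19.8% as its reading, compound 3 (`C/C(=N/O)c1ccc(NC(=O)Cn2nc(-c3ccccc3)nc2N)cc1`) gives 34% as its reading, and compound 2 (`C/C(=N/O)c1ccc(NC(=O)Cn2nc(C(F)(F)F)nc2N)cc1`) gives 25.6% as its reading, within the scatter of both others. Compound 4 (`CC(=O)c1ccc(NC(=O)Cn2nc(C(F)(F)F)nc2N)cc1`) follows from compound 2 through one change: a group of 3 heavy atoms (2 carbon, 1 oxygen; no ring) in place of a group of 4 heavy atoms (2 carbon, 1 nitrogen, 1 oxygen; no ring), on an aromatic carbon (acetyl enters on an aromatic carbon, para to a large group). Among the compounds with values here, the one measured step, a number 8.4 percentage points higher from compound 2 to compound 3 (within the scatter) with phenyl in place of trifluoromethyl, lies at another place and bears only indirectly. Compound 1 also carries acetyl, but its other substituent differs. No shift beyond the scatter is therefore expected in this assay for this change. Estimated for the change is a number 2.6 percentage points lower from compound 2 to compound 4 (within the scatter) at this stage. For compound 4 the estimate is 23% with an expected range from 10% to 36% in this read-out.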

Compound 4, percent growth inhibition at one concentration: 14.6%
Beside the measured number, compound 4's estimate is 8.4 percentage points above it; the range from low to high includes it.
By their numbers in this assay, from the lowest: compounds 4, 1, 2 and 3 (each within the scatter of the next, the first and the last beyond it).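

Within the data shown here, with trifluoromethyl held constant, acetyl on the aromatic carbon para to a large group gives less growth inhibition in this assay with a number 11 percentage points lower from compound 2 to compound 4 (beyond the scatter) as the first step beyond the scatter. Among the acetyl compounds, a number 5.2 percentage points lower from compound 1 to compound 4 (within the scatter) does not separate trifluoromethyl from 4-chlorophenyl. Nothing at hand bears on the reason for the step from the group of 4 heavy atoms to acetyl.

Going by these compounds, whether this loss also holds with phenyl on the other side of the molecule remains open. Also open, on these data alone, is how a carboxylic acid or an amine at this position would compare with acetyl.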